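This account rests on a few compounds, and the source may have more. Where it says the series, first, only, none or still open, it means among the compounds named here.

Measured compounds:
Compound 1 `CCCCCc1cc2ccccc2nc1-c1cc(-c2ccccc2)no1`: in a functional assay on A549 cells (Homo sapiens) for inhibition, read by MTT assay, with a stated time of 24 h (on this read-out lower numbers stand for stronger inhibition and higher numbers for weaker inhibition), compound 1 gives 92300 nM.
Compound 2 `CCc1cc2ccccc2nc1-c1cc(-c2ccc(C)cc2)no1`: in this assay compound 2 gives > 100000 nM, which is a limit of the assay and not a number.
Compound 3 `CCCCc1cc2ccccc2nc1-c1cc(-c2ccc(C)cc2)no1`: in this assay compound 3 gives > 100000 nM, likewise a limit of the assay and not a number.

Compound 3 therefore stands at the limit, and so does compound 2 (the limit of > 100000 nM in this assay, at which 2 of the 3 values shown sit); compound 1 is the only one of the three with a measured number. Compound 4 `CCCCCc1cc2ccccc2nc1-c1cc(-c2ccc(C)cc2)no1` differs from compound 3 by methyl in place of hydrogen on a saturated chain carbon, four bonds along the chain from an aromatic carbon. Going by the values given here, the only measured step on the same chain is a step that the two limits leave unreadable from compound 2 to compound 3, which runs between two limits and yields no readable size. Among the compounds with values here, compound 1 carries the same chain length as compound 4 but differs from it elsewhere, and no step links them; its value shows only a weak, measurable number. With two limits and one weak number in hand, compound 4 is expected to sit at or near the limit as well, the step of a number no higher from compound 3 to compound 4 (the limit leaves the size open) being an estimate without support from any readable step. Compound 4 is estimated at 100000 nM, with a range from 40000 nM to 300000 nM.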

Compound 4, half-maximal inhibitory concentration: > 100000 nM
Compound 4: no number, only a limit (the forecaster's own chance of this, stated with the estimate: 60%); the middle value sits exactly at the limit.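

In this assay compound 4 gives > 100000 nM, which is a limit of the assay and not a number. The steps from compound 2 and from compound 3 to compound 4 cannot be read, so methyl in place of hydrogen on a saturated chain carbon, four bonds along the chain from an aromatic carbon, has no readable size here, and the limit now holds most of the set: the limit of > 100000 nM in this assay, at which 3 of the 4 values shown sit. The one readable link is new: methyl in place of hydrogen on an aromatic carbon gives an at least 1.0-fold higher number from compound 1 to compound 4 (0.03 log units; that floor lies within the scatter), which does not separate the two compounds.

From the compounds shown here alone, the true size of that step on the aromatic carbon stays open, as compound 4 has only a limit. Going by these compounds, whether an amine or a carboxylic acid in place of the chain would bring the series off the limit also stays open.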